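The source may report more compounds than this note shows. Statements on the series, on what has been measured and on what is new or still open speak of the compounds shown alone.

In an ADME assay on microsomes from liver (Homo sapiens) for pharmacokinetics, read by LC-MS, with a stated time of 60 min, tested at 1 uM (a lower number here means slower removal, a higher number faster removal of the compound), compound 2 `O=C(NCc1ccc(S(=O)(=O)N2CCOCC2)cc1)N1Cc2ccncc2C1` gives 9 mL/min/kg and sits within the scatter of compound 1 `O=C(NCc1ccc(S(=O)(=O)C2CCN(C3COC3)CC2)cc1)N1Cc2ccncc2C1` at 10 mL/min/kg as the only other measured point. Compound 3 `O=C(NCc1ccc(S(=O)(=O)N2CCC(O)CC2)cc1)N1Cc2ccncc2C1` carries 4-hydroxypiperidin-1-yl in place of morpholin-4-yl on a sulfonyl sulfur. For the measured compounds named here, the one measured step at this place (a 1.1-fold lower number from compound 1 to compound 2 (0.05 log units; within the scatter)) stays within the scatter, so no step beyond the scatter is expected in this assay for this change. The expected step (a 1.1-fold higher number from compound 2 to compound 3 (0.05 log units; within the scatter)) is small. For compound 3 the estimate is 10 mL/min/kg with an expected range from 6 mL/min/kg to 17 mL/min/kg on this read-out.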

Compound 3, clearance in the Homo sapiens assay: 6 mL/min/kg
For compound 3 the middle estimate is 1.7-fold (0.22 log units) above the measured one; the measured number falls inside the stated range.
By their numbers in the Homo sapiens assay, from the lowest: compounds 3, 2 and 1 (each within the scatter of the next).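

In the Homo sapiens assay this place on the sulfonyl sulfur takes 4-hydroxypiperidin-1-yl with no step beyond the scatter, whether against morpholin-4-yl (a 1.5-fold lower number from compound 2 to compound 3 (0.18 log units; within the scatter)) or against 1-(oxetan-3-yl)piperidin-4-yl (a 1.7-fold lower number from compound 1 to compound 3 (0.22 log units; within the scatter)). The same change from morpholin-4-yl is the only step shown at this place that goes beyond the scatter, and it does so in a physicochemical assay for solubility, in phosphate buffer, with a stated time of 24 h, at pH 7.4, tested at 100 uM; on this read-out higher numbers stand for higher solubility and lower numbers for lower solubility: the measured solubility of compound 2, 59000 nM, and of compound 3, 174000 nM, a 2.9-fold higher number (0.47 log units; beyond the scatter). In the physicochemical assay compound 2 gives 59000 nM and compound 3 gives 174000 nM.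

From the compounds shown here alone, how a piperidine ring carrying an amine or a carboxylic acid in place of the hydroxy group would read in the Homo sapiens assay and in the physicochemical assay stays open.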